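Pyridin-4-yl Replaces Methoxy on a Fused Pyrazole Core

The source may hold more compounds than are shown below. What is called first, only, known or untested is meant among the compounds shown, and "the series" means these compounds.

Two compounds have been measured in a functional assay on COLO 205 cells (Homo sapiens) for antiproliferative activity, read by MTT assay, with a stated time of 68 h; on this read-out lower numbers stand for stronger inhibition and higher numbers for weaker inhibition:

Compound 1, `O=S(=O)(Nc1ccc(F)c(C#Cc2cnc3[nH]ncc3c2)c1F)c1ccccn1`: 2670 nM
Compound 2, `COc1n[nH]c2ncc(C#Cc3c(F)ccc(NS(=O)(=O)c4cccnc4)c3F)cc12`: 89 nM

Compound 2 gives the lower of the two numbers, and the number for compound 1 lies beyond the usual scatter above it. Among the compounds with values here, the two differ in more than one place, so no single step links them. Compound 3, `O=S(=O)(Nc1ccc(F)c(C#Cc2cnc3[nH]nc(-c4ccncc4)c3c2)c1F)c1cccnc1`, has not yet been measured. It differs from compound 2 by pyridin-4-yl in place of methoxy on an aromatic carbon. Within the data shown here, no measured step of this kind exists here, so the change expected from compound 2 to compound 3 is a 1.3-fold higher number from compound 2 to compound 3 (0.13 log units; within the scatter), within the scatter. Compound 3 is therefore estimated at 120 nM, with a range from 25 nM to 500 nM.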

Compound 3, half-maximal inhibitory concentration: 78 nM
For compound 3 the middle estimate is 1.5-fold (0.19 log units) above the measured one; the range from low to high includes it.
By their numbers in this assay, from the lowest: compounds 3 and 2 (each within the scatter of the next); then compound 1.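

In this assay, pyridin-4-yl in place of methoxy on this aromatic carbon gives a 1.1-fold lower number from compound 2 to compound 3 (0.06 log units; within the scatter). This position, on the five-membered ring of the core, can therefore carry a whole six-membered aromatic ring as well as methoxy, with the two numbers matching within the scatter. Nothing available explains this match.

From the compounds shown here alone, whether an amine or a carboxylic acid on this carbon would also keep the number stays open. Going by these compounds, compound 1 differs from compound 2 in more than one place, so the share of this position in their gap also remains unknown.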